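This account rests on a few compounds, and the source may have more. Where it says the series, first, only, none or still open, it means among the compounds named here.

Compound 1 `Cc1c(C(=O)N/N=C/c2ccc(C(F)(F)F)cc2)no[n+]1[O-]`: > 400000 nM
Compound 2 `Cc1c(/C=N/NC(=O)c2ccncc2)no[n+]1[O-]`: > 400000 nM
Compound 3 `Cc1c(C(=O)N/N=C/c2cccs2)ns[n+]1[O-]`: > 400000 nM

Every value recorded in an ADME assay on J774.1 cells (Mus musculus) for cytotoxicity, read by MTT assay, with a stated time of 48 h (a higher number here means a weaker inhibitor, a lower number a stronger inhibitor), is a limit of the assay, not a number. Compound 1 sits at that limit, as do the other two compounds, so nothing in these values separates any of the three from another (the limit of > 400000 nM in this assay, at which 3 of the 3 values shown sit). Compound 4 `Cc1c(C(=O)N/N=C/c2ccc(C(=O)O)cc2)no[n+]1[O-]` differs from compound 1 by carboxy in place of trifluoromethyl on an aromatic carbon. For the measured compounds named here, no step between two measured compounds is available, so the size of this change cannot be read from any measured pair. The expected step is a step that the limit leaves unreadable from compound 1 to compound 4, that is, none beyond the scatter, with the result most likely reported again as a limit. Compound 4 is estimated at 450000 nM, in the range 200000 nM to 900000 nM.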

Compound 4, half-maximal inhibitory concentration: > 300000 nM
Compound 4: only a limit was reported (the forecaster's own chance of this, stated with the estimate: 85%); the middle value does not contradict the limit.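

For the compounds shown here, compound 1 and compound 4 are both recorded only as limits, and no step between them can be read. The compounds shown leave open what concentration of any of them, if any, would reach half-maximal inhibition in this assay.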